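The source may hold more compounds than are shown below. What is called first, only, known or untested is meant among the compounds shown, and "the series" means these compounds.

Series notes, A-375 cell growth. Compound 2 `CCCCCCc1nc(N)n(CC(=O)Nc2ccc(C)cc2)c1-c1ccccc1Br` carries an anilide ring with a methyl group in place of the ring hydrogen present in compound 1 `CCCCCCc1nc(N)n(CC(=O)Nc2ccccc2)c1-c1ccccc1Br`. In a functional assay on A-375 cells (Homo sapiens) for antiproliferative activity, read by MTT assay, with a stated time of 48 h (on this read-out higher numbers stand for weaker inhibition and lower numbers for stronger inhibition), compound 1 gives 5700 nM, and in this assay compound 2 gives 5100 nM; the two numbers lie within the usual scatter of each other, so compound 2 stands level with compound 1 and no order between them can be read. Among the measured compounds shown here, the one measured step, a 1.1-fold lower number from compound 1 to compound 2 (0.05 log units; within the scatter), shows that the methyl on the anilide ring leaves the read-out essentially unchanged.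

Compound 3 `Cc1ccc(NC(=O)Cn2c(N)nc(CC3CCCCC3)c2-c2ccccc2Br)cc1` alters a different part of the molecule: cyclohexyl in place of pentyl on a saturated chain carbon bound to an aromatic carbon. For the measured compounds named here, no measured step touches this chain, so the only step available, a 1.1-fold lower number from compound 1 to compound 2 (0.05 log units; within the scatter), bears on it indirectly at most, showing merely that a small peripheral change left the numbers where they were. With the chain closed into a ring of the same carbon count plus one, the expectation is a step no larger than the scatter, direction open, and the estimated step of a 1.1-fold lower number from compound 2 to compound 3 (0.05 log units; within the scatter) expresses that. For compound 3 the expected value in this assay is 4500 nM, with a range from 1500 nM to 13000 nM.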

Compound 3, half-maximal inhibitory concentration: 17500 nM
Compound 3: middle estimate off by 3.9-fold (0.59 log units), on the low side; measured number outside the range, above it.
By their numbers in this assay, from the lowest: compounds 2 and 1 (each within the scatter of the next); then compound 3.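

Unlike the anilide ring, where the methyl step a 1.1-fold lower number from compound 1 to compound 2 (0.05 log units; within the scatter) changes nothing that can be read, the saturated chain carbon bound to an aromatic carbon responds in this assay: cyclohexyl in place of pentyl gives a 3.4-fold higher number from compound 2 to compound 3 (0.54 log units; beyond the scatter), a modest step towards weaker inhibition. This position is therefore the first in the series where a change moves the read-out beyond the scatter, and in this pair the open chain carries the lower number. The same difference also reads as hexyl to cyclohexylmethyl, so this single pair cannot separate the presence of the ring from the change in the group's size, and no measurement at hand accounts for the step.

The compounds shown leave open whether a longer chain such as octyl, a smaller ring such as cyclopentyl or an aromatic phenyl ring at this place would fall on the side of pentyl or of cyclohexyl, and what an amine or a carboxylic acid at the end of the chain would do. They also leave open whether the step holds on the plain anilide of compound 1, since cyclohexyl appears here only with the methyl-bearing anilide.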